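A few compounds are considered here, and "the series" means these few. Any claim that something is new, unique, unknown or untested is made for them only; others in the source may bear on it.

Measured compounds:
compound 1, `COc1cc2c(/C=C3/C(=O)Nc4ccc(Cl)cc43)c(Cl)n(Cc3cc(OC)c(OC)c(OC)c3)c2cc1C`, 5890 nM
compound 2, `COc1ccc2c(c1)/C(=C\c1c(Cl)n(Cc3cc(OC)c(OC)c(OC)c3)c3cc(C)c(OC)cc13)C(=O)N2`, 97700 nM
compound 3, `COc1c(/C=C2/C(=O)Nc3ccc(Cl)cc32)c2ccccc2n1-c1ccccc1`, 24600 nM

These three compounds were tested in a functional assay on NSCLC cells (Homo sapiens) for cytotoxicity, with a stated time of 48 h; a higher number here means a weaker inhibitor of growth, a lower number a stronger inhibitor of growth. Compound 1 and compound 2 share a core and differ by one change, (methoxy in place of chloro on an aromatic carbon), and that single change made a large step: a 17-fold higher number from compound 1 to compound 2 (1.22 log units; beyond the scatter). Compound 3 is built on another core; the difference between the two cores is not broken down here. In this assay compound 3 gives 24600 nM, which stands between the other two numbers.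

Compound 4, `COc1ccc2c(c1)/C(=C\c1c(OC)n(-c3ccccc3)c3ccccc13)C(=O)N2`, is not yet measured. It differs from compound 3 by methoxy in place of chloro on an aromatic carbon, and the place of the change is the same as between compound 1 and compound 2, so this is the same change made on a second core. If the change acts on the core of compound 3 as it did on the core of compound 1, the number is expected to rise by a comparable margin, so compound 4 is expected to fall near 150000 nM, within 40000 nM to 500000 nM. This expectation means a step of a 6.1-fold higher number from compound 3 to compound 4 (0.79 log units; beyond the scatter), resting on the step from compound 1 to compound 2, a 17-fold higher number from compound 1 to compound 2 (1.22 log units; beyond the scatter), and on the starting number of compound 3, 24600 nM. Because compound 2 already gives 97700 nM, a number in the expected range for compound 4 would stand at the high end of what has been measured among these compounds.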

Compound 4, concentration for total growth inhibition: 17400 nM
Compound 4: middle estimate off by 8.6-fold (0.94 log units), on the high side, and the stated range ends above it.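

Swapping chloro for methoxy on an aromatic carbon did not have the same effect on both cores. In this assay, the swap gives a 1.4-fold lower number from compound 3 to compound 4 (0.15 log units; within the scatter), so compound 3 and compound 4 cannot be told apart, and the two steps clearly disagree: the same change on two cores in this assay, a 17-fold higher number (1.22 log units; beyond the scatter) from compound 1 to compound 2 and a 1.4-fold lower number (0.15 log units; within the scatter) from compound 3 to compound 4, 23-fold (1.37 log units) apart, beyond the scatter of two such steps

The large rise in the number seen on the core of compound 1 therefore cannot be assumed to carry over to another core in this series, and the size of this change depends on the core, at least in these two pairs. The pairs do not show why, since the two cores differ in more than one place and the comparison cannot single out the part that matters.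

The compounds shown compare only chloro and methoxy at this place, leaving open how an amine or a carboxylic acid there would behave on either core. Also open, from the compounds shown here alone, is whether the change would follow either pattern on a third core.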